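This account rests on a few compounds, and the source may have more. Where it says the series, first, only, none or still open, it means among the compounds named here.

In an ADME assay on WI-38 cells (Homo sapiens) for cytotoxicity, read by MTT assay, with a stated time of 72 h (a lower number here means a stronger inhibitor, a higher number a weaker inhibitor), three amides sharing one core have been measured. Compound 1 `O=C(CCc1cccc2c1B(O)OC2)NC1CCCCC1` gives > 100000 nM, which is a limit. Compound 2 `O=C(CCc1cccc2c1B(O)OC2)Nc1nccs1` gives > 100000 nM, which is also a limit. Compound 3 `Cc1ccc(NC(=O)CCc2cccc3c2B(O)OC3)cc1` gives > 100000 nM, again a limit and not a number. It therefore stands with the other two, and the whole set rests on (the limit of > 100000 nM in this assay, at which 3 of the 3 values shown sit).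

Compound 4 `CC(C)(C)OC(=O)NCc1ccc(NC(=O)CCc2cccc3c2B(O)OC3)cc1` differs from compound 3 by (tert-butoxycarbonyl)amino in place of hydrogen on a saturated chain carbon bound to an aromatic carbon, which turns methyl into ((tert-butoxycarbonyl)amino)methyl. The nearest measured evidence is a step that the two limits leave unreadable from compound 1 to compound 2, a step that the two limits leave unreadable from compound 1 to compound 3 and a step that the two limits leave unreadable from compound 2 to compound 3. All three change the group on an amide-type nitrogen, so none tests this new group, and none has a readable size. The expectation therefore rests on compound 3 and its limit of > 100000 nM, and no step beyond the scatter is expected in this assay. The expected change is a number no higher from compound 3 to compound 4 (the limit leaves the size open). Compound 4 is estimated at 100000 nM, with an expected range from 30000 nM to 150000 nM, and will most likely be reported as a limit again.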

Compound 4, half-maximal inhibitory concentration: 4800 nM
Beside the measured number, compound 4's estimate is 21-fold (1.32 log units) above it; measured number outside the range, below it.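

In this assay, ((tert-butoxycarbonyl)amino)methyl in place of methyl gives an at least 20-fold lower number from compound 3 to compound 4 (1.31 log units; beyond the scatter). For the compounds shown here, the steps among compound 1, compound 2 and compound 3 cannot be read, and all of them change the group on an amide-type nitrogen, so this change on a saturated chain carbon bound to an aromatic carbon is the first in the set with a readable size. It also gives the only value here that is a number and not a limit: the limit of > 100000 nM in this assay, at which 3 of the 4 values shown sit.

What the compounds shown leave open is which part of the (tert-butoxycarbonyl)amino group goes with the lower number, as a free amine or an acetamide at the same place could answer. On these data alone, it is also open whether the same group would lower the number on the thiazole of compound 2 or the cyclohexyl of compound 1.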